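This account rests on a few compounds, and the source may have more. Where it says the series, first, only, none or still open, it means among the compounds named here.

Within the data shown here, in a functional assay on HCT-116 cells (Homo sapiens) for inhibition, read by crystal violet staining and colony formation, with stated times of 72 h and 7 days (a higher number here means that more compound is needed for the effect, a lower number that less compound is needed), compound 3 (`O=C(Nc1ccc(Sc2nc3ccccc3s2)c(Cl)c1)c1cccc(Br)c1O`) gives 17000 nM and so holds the second highest of the three numbers so far. Compound 1 (`COc1ccc(S(=O)(=O)Nc2ccc3oc(-c4ccc(NC(=O)c5cccc(C)c5[N+](=O)[O-])cc4)nc3c2)cc1`) at 19000 nM lies within the scatter of it, while compound 2 (`COc1ccc(S(=O)(=O)Nc2ccc3oc(-c4ccc(NC(=O)c5ccc(Cl)s5)cc4)nc3c2)cc1`) at 2700 nM lies clearly lower. Compound 4 (`COc1c(Br)cccc1C(=O)Nc1ccc(Sc2nc3ccccc3s2)c(Cl)c1`) differs from compound 3 by methyl in place of hydrogen on an oxygen on an aromatic ring and this amounts to hydroxy to methoxy, a methyl in place of hydrogen on an oxygen on an aromatic ring. Among the measured compounds shown here, the one measured step (a 7.0-fold lower number from compound 1 to compound 2 (0.85 log units; beyond the scatter)) puts 5-chlorothiophen-2-yl in place of 3-methyl-2-nitrophenyl on a carbonyl carbon, on the core of compound 1. It is modest and touches neither this place nor the core of compound 3, so it offers only a rough scale. For the measured compounds named here, no measured pair shows what this change does. In this assay no step beyond the scatter is therefore expected, and the estimated change (a 1.2-fold higher number from compound 3 to compound 4 (0.07 log units; within the scatter)) leans slightly toward a higher number. Compound 4 is expected at 20000 nM with an estimated range from 7000 nM to 60000 nM as its likely span.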

Compound 4, half-maximal effective concentration: 11000 nM
Compound 4: middle estimate off by 1.8-fold (0.26 log units), on the high side, and the stated range covers the measured number.
By their numbers in this assay, from the lowest: compound 2; then compounds 4, 3 and 1 (each within the scatter of the next).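

In this assay, among these compounds, the step from hydroxy to methoxy, a 1.5-fold lower number from compound 3 to compound 4 (0.19 log units; within the scatter), gives the first measured reading of this position, and methyl in place of hydrogen on an oxygen on an aromatic ring leaves the two numbers within the scatter of each other. Among the compounds shown here, on this core, then, the hydrogen on this oxygen can be exchanged for methyl with no step beyond the scatter, whereas the only earlier step, a 7.0-fold lower number from compound 1 to compound 2 (0.85 log units; beyond the scatter), concerned another place on another core and said nothing about this oxygen. No measurement shown bears on why this change has so small a reach.

The compounds shown leave open whether a longer chain on this oxygen, such as ethyl or propyl, or an amine in place of the hydroxy, would give a step beyond the scatter. They also leave open whether the same change would read alike on the core of compound 1.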